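Para-substituent change on an aryl thioester series

The source may hold more compounds than are shown below. What is called first, only, known or untested is meant among the compounds shown, and "the series" means these compounds.

Measured so far:
compound 1, `O=C(S[C@]12CC[C@H](O)[C@H]1C(=O)NC2=O)c1ccc(O)cc1` — 141000 nM
compound 2, `O=C(S[C@]12CC[C@H](O)[C@H]1C(=O)NC2=O)c1ccccc1` — 65200 nM

Compound 2 gives the lowest of the two numbers measured in a functional assay on RAW264.7 cells (Mus musculus) for inhibition, read by Griess assay, with a stated time of 24 h; on this read-out lower numbers stand for stronger inhibition and higher numbers for weaker inhibition; its nearest neighbour is compound 1, which differs from it by a 2.2-fold lower number from compound 1 to compound 2 (0.33 log units; beyond the scatter). That single step, hydrogen in place of hydroxy on an aromatic carbon, is the only one measured so far.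

Compound 3, `O=C(S[C@]12CC[C@H](O)[C@H]1C(=O)NC2=O)c1ccc(F)cc1`, has not yet been measured. It differs from compound 2 by fluoro in place of hydrogen on an aromatic carbon. Going by the values given here, the one measured step bears on this only loosely: it shows that exchanging the group at this position on the ring can move the number by a modest amount, as seen from compound 1 to compound 2, but it does not show the direction for a fluoro group, which replaces only a hydrogen. The expectation is therefore a step of a 1.2-fold lower number from compound 2 to compound 3 (0.07 log units; within the scatter) in this assay, at most a small shift around the value of compound 2. The estimate for compound 3 is 55000 nM, with a plausible range from 25000 nM to 120000 nM.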

Compound 3, half-maximal inhibitory concentration: 318000 nM
Estimate against measurement, compound 3: 5.8-fold (0.76 log units) below, and the stated range ends below it.
By their numbers in this assay, from the lowest: compound 2; then compound 1; then compound 3.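

In this assay, a single fluoro on the ring, para to a large group, does not leave the number where it was: the phenyl to 4-fluorophenyl change gives a 4.9-fold higher number from compound 2 to compound 3 (0.69 log units; beyond the scatter). Fluoro and hydroxy also differ from each other at this position, with a 2.3-fold higher number from compound 1 to compound 3 (0.35 log units; beyond the scatter), so the kind of group placed there matters and not only whether the hydrogen is replaced. Both groups now give higher numbers than hydrogen, which makes the unsubstituted ring of compound 2 the strongest inhibitor of these three compounds, although no measurement at hand accounts for this order.

Going by these compounds, with only hydroxy and fluoro to compare against hydrogen, it remains open whether every replacement at this position raises the number, or whether a group such as chloro, methoxy, an amine or a carboxylic acid could bring it below that of compound 2. It is also unknown whether the same order would hold on a different core or with a different group in place of the thioester link.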